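The source may report more compounds than this note shows. Statements on the series, on what has been measured and on what is new or still open speak of the compounds shown alone.

In a functional assay on MCF7 cells (Homo sapiens) for cytotoxicity (a lower number here means a stronger inhibitor, a higher number a weaker inhibitor), compound 1 (`COc1c(O)cc2c3c1C[C@@H](C)C[C@H](OC)[C@H](O3)[C@@H](C)/C=C(\C)[C@H](OC(N)=O)[C@@H](OC)/C=C\C=C(/C)C(=O)N2`) gives 20000 nM, and compound 2 (`COc1c(O)cc2c3c1C[C@@H](C)C[C@H](OC)[C@H](O3)[C@@H](C)/C=C(\C)[C@H](OC(N)=O)[C@@H](OC)/C=C/C=C(\C)C(=O)N2`) gives 36000 nM. These two values lie within the scatter of each other, so compound 2 cannot be separated from compound 1 on these numbers. Compound 3 (`COc1c(O)cc2c3c1C[C@@H](C)C[C@H](OC)[C@H](O3)[C@@H](C)/C=C(\C)[C@H](OC(N)=O)[C@@H](OC)/C=C\C=C(\C)C(=O)N2`) has not yet been measured. For the move to it, (the two compounds have the same atoms and bonds and differ only in configuration as drawn: 2 of 9 stereo elements differ; a double bond is drawn E in compound 2 and Z in compound 3; a double bond is drawn E in compound 2 and Z in compound 3). No atoms leave and none enter.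

Within the data shown here, only one measured step bears on this change: a 1.8-fold higher number from compound 1 to compound 2 (0.26 log units; within the scatter). That step rests on (the fact that compounds 1 and 2 differ only in the configuration as drawn), and it involves a single double bond. No measurement covers two double bonds changing together, so the evidence for compound 3 is thin. With a single configurational change having moved this assay by no more than the scatter, no clear shift is expected here, and a weak cytotoxic reading seems likely to persist. The expected change is a 1.4-fold lower number from compound 2 to compound 3 (0.14 log units; within the scatter), which would not stand beyond the scatter. For compound 3 the estimated value is 26000 nM, with an expected range of 10000 nM to 60000 nM.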

Compound 3, half-maximal inhibitory concentration: 35000 nM
The estimate for compound 3 lay 1.3-fold (0.13 log units) below the measured number, within the range that was stated.
By their numbers in this assay, from the lowest: compounds 1, 3 and 2 (each within the scatter of the next).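

Compound 3 supplies what the earlier pair could not: a case in which two double bonds differ together, and in this assay this gives a 1.0-fold lower number from compound 2 to compound 3 (0.01 log units; within the scatter). Among these compounds, the single change from compound 1 to compound 3 involves a different double bond from the one in the earlier step, and it gives a 1.8-fold higher number from compound 1 to compound 3 (0.24 log units; within the scatter), so each of the two double bonds has now been examined alone and neither step leaves the scatter. Across these three compounds, then, the geometry of these double bonds, whether altered singly or jointly, does not separate the readings, and this holds for compounds whose only difference is configuration as drawn: the fact that compounds 2 and 3 differ only in the configuration as drawn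

On these data alone, the remaining arrangement of the two double bonds stays open, as does whether geometry would matter in a compound with stronger readings in this assay. As far as these compounds go, all three compounds share the same atoms and bonds, so it is also open whether an amine or a carboxylic acid on the shared core would give a reading that stands apart from these.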